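The source may report more compounds than this note shows. Statements on the series, on what has been measured and on what is new or still open speak of the compounds shown alone.

Going by the values given here, compound 3, with the structure `Oc1ccccc1/C=N/c1nnc(SCc2c[se]c(-c3ccccc3)n2)s1`, sits second highest of the three numbers so far in a functional assay on MCF7 cells (Homo sapiens) for antiproliferative activity, read by CCK-8 assay (a lower number here means a stronger inhibitor, a higher number a weaker inhibitor), where compound 3 gives 15200 nM. Its nearest neighbour is compound 1, the structure `C(=N/c1nnc(SCc2c[se]c(-c3ccccc3)n2)s1)\c1ccccc1`, for which compound 1 gives 25600 nM; the furthest is compound 2, the structure `Clc1ccc(/C=N/c2nnc(SCc3c[se]c(-c4ccccc4)n3)s2)cc1`, for which compound 2 gives 4020 nM. The step of a 1.7-fold lower number from compound 1 to compound 3 (0.23 log units; within the scatter) lies within the scatter, whereas a 6.4-fold lower number from compound 1 to compound 2 (0.80 log units; beyond the scatter) and a 3.8-fold higher number from compound 2 to compound 3 (0.58 log units; beyond the scatter) are modest but real.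

Compound 4 has the structure `COc1cc(/C=N/c2nnc(SCc3c[se]c(-c4ccccc4)n3)s2)ccc1O` and is not yet measured. It differs from compound 3 in one place: 4-hydroxy-3-methoxyphenyl in place of 2-hydroxyphenyl on a carbon with a double bond to nitrogen. Among the compounds with values here, none of the measured steps changes the ring in this way. The closest comparison is a 1.7-fold lower number from compound 1 to compound 3 (0.23 log units; within the scatter), where adding a hydroxy group moved the number only within the scatter, while a 6.4-fold lower number from compound 1 to compound 2 (0.80 log units; beyond the scatter) shows that a single substituent on that ring can shift the number modestly. On this basis compound 4 is expected to land near compound 3, with any step in this assay likely small and uncertain in direction.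

Compound 4 is therefore estimated at 10000 nM, within a range of 3000 nM to 35000 nM, which corresponds to an expected step of a 1.5-fold lower number from compound 3 to compound 4 (0.18 log units; within the scatter).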

Compound 4, half-maximal inhibitory concentration: 15000 nM
Estimate against measurement, compound 4: 1.5-fold (0.18 log units) below; low and high end bracket the measured number.
By their numbers in this assay, from the lowest: compound 2; then compounds 4, 3 and 1 (each within the scatter of the next).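

In this assay, replacing 2-hydroxyphenyl with 4-hydroxy-3-methoxyphenyl gives a 1.0-fold lower number from compound 3 to compound 4 (0.01 log units; within the scatter), so this position accepts the larger group, with 9 heavy atoms in place of 7, without a change that can be read. The same holds against the plain phenyl group, with a 1.7-fold lower number from compound 1 to compound 4 (0.23 log units; within the scatter), so compound 1, compound 3 and compound 4 now form a set of three that cannot be told apart, although two of them carry a hydroxy group and one also carries a methoxy group. The contrast with the 4-chlorophenyl group stays, with a 3.7-fold higher number from compound 2 to compound 4 (0.57 log units; beyond the scatter), and compound 2 is now the strongest of the four, since its steps to all three others are printed as beyond the scatter.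

No measurement at hand explains why the chloro compound stands apart or why the other three rings stay level. Still open, on these data alone, is whether the advantage of compound 2 belongs to chlorine alone or would also appear with a fluoro, bromo, trifluoromethyl or nitro group on that ring, and how an amine or a carboxylic acid there would read in this assay.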